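Sulfonyl substituent series: aryl, benzyl, anilino on the core

The source may report more compounds than this note shows. Statements on the series, on what has been measured and on what is new or still open speak of the compounds shown alone.

For the measured compounds named here, compound 3 `Cn1c(=O)c(S(=O)(=O)Nc2ccc(F)cc2F)cc2cnc(Nc3ccc4[nH]ccc4c3)nc21` stands as the weakest of the three measured members in a functional assay on DU-145 cells (Homo sapiens) for inhibition, read by trypan blue exclusion, with a stated time of 72 h; a lower number here means a stronger inhibitor, a higher number a weaker inhibitor: compound 3 gives 5000 nM. Compound 1 `Cn1c(=O)c(S(=O)(=O)Cc2ccc(F)cc2F)cc2cnc(Nc3ccc4[nH]ccc4c3)nc21` carries 2,4-difluorobenzyl on the sulfonyl sulfur and gives 1000 nM; compound 2 `Cn1c(=O)c(S(=O)(=O)c2ccc([N+](=O)[O-])cc2F)cc2cnc(Nc3ccc4[nH]ccc4c3)nc21`, with 2-fluoro-4-nitrophenyl on that sulfur, gives 400 nM. Both steps that lead to compound 3 run against it: a 5.0-fold higher number from compound 1 to compound 3 (0.70 log units; beyond the scatter) and a 13-fold higher number from compound 2 to compound 3 (1.10 log units; beyond the scatter). Between the other two members the step is a 2.5-fold lower number from compound 1 to compound 2 (0.40 log units; beyond the scatter).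

Compound 4 `Cn1c(=O)c(S(=O)(=O)c2ccc(Cl)cc2Cl)cc2cnc(Nc3ccc4[nH]ccc4c3)nc21` is the next member. 2,4-dichlorophenyl in place of (2,4-difluorophenyl)amino on a sulfonyl sulfur The change removes the (2,4-difluorophenyl)amino group and places a 2,4-dichlorophenyl directly on the sulfonyl sulfur, so compound 4 resembles compound 2, where a six-membered aromatic ring of carbon only sits on that sulfur, rather than compound 3. The step that bears most directly is a 13-fold higher number from compound 2 to compound 3 (1.10 log units; beyond the scatter), which compound 4 would reverse; a 5.0-fold higher number from compound 1 to compound 3 (0.70 log units; beyond the scatter) points the same way. The number for compound 4 is therefore expected to fall well below that of compound 3, by about a 10-fold lower number from compound 3 to compound 4 (1.00 log units; beyond the scatter). No chlorine-bearing group on the sulfonyl sulfur has been measured in this set, so the range is kept wide. For compound 4 the estimate is 500 nM, with a range of 150 nM to 2000 nM.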

Compound 4, half-maximal inhibitory concentration: 1000 nM
Estimate against measurement, compound 4: 2.0-fold (0.30 log units) below, and the stated range covers the measured number.
By their numbers in this assay, from the lowest: compound 2; then compounds 1 and 4 (each within the scatter of the next); then compound 3.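

Putting 2,4-dichlorophenyl in place of (2,4-difluorophenyl)amino on the sulfonyl sulfur gives a 5.0-fold lower number from compound 3 to compound 4 (0.70 log units; beyond the scatter), so compound 3 remains the weakest of the four, now also against a second member with an aromatic ring attached directly to that sulfur. Those two directly attached rings do not match: the change between them gives a 2.5-fold higher number from compound 2 to compound 4 (0.40 log units; beyond the scatter), so among these compounds a six-membered aromatic ring of carbon only on the sulfur does not by itself bring the number down to that of compound 2, and what the ring carries also matters. The 2,4-dichlorophenyl and 2,4-difluorobenzyl groups are not separated, with no change at the digits printed from compound 1 to compound 4 (within the scatter), although they differ both in how the ring is attached and in its halogens, so neither difference can be assessed alone.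

No measurement available here accounts for these differences. Still open, going by these compounds, are the result of 2,4-difluorophenyl attached directly to the sulfonyl sulfur, which would separate the halogen from the attachment, and the effect of an amine, a carboxylic acid or a longer chain on that sulfur.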